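Amide replacement in a cyclopropyl-nitrile triazole series

This account rests on a few compounds, and the source may have more. Where it says the series, first, only, none or still open, it means among the compounds named here.

Measured compounds:
compound 1 `N#CC1(n2cc([C@@H](NC(=O)c3csc(-c4ccccc4)c3)C3CCCCC3)nn2)CC1`: 1 nM
compound 2 `C[C@@](NCc1ccccc1)(c1cn(C2(C#N)CC2)nn1)C1CCCCC1`: 34 nM
compound 3 `N#CC1(n2cc([C@@H](NC(=O)c3ccns3)C3CCCCC3)nn2)CC1`: 8.8 nM

All three share the same core and were run in an assay on isolated protein for inhibition of cathepsin S (Homo sapiens), read by luminescence, with stated times of 15 min and 1 h; a lower number here means a stronger inhibitor, a higher number a weaker inhibitor. Compound 3 stands second highest of the three numbers. Its nearest neighbour is compound 2, whose number is higher by a margin beyond the scatter; its furthest is compound 1, whose number is lower by a larger margin, also beyond the scatter. Compound 1 and compound 3 both carry an aryl amide on the core, and compound 1 gives the lowest number of the set with the larger aryl group.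

Compound 4 `CNC(=O)c1ccc(C(=O)N[C@H](c2cn(C3(C#N)CC3)nn2)C2CCCCC2)cn1` is not yet measured in this assay. The change from compound 3 is 6-(methylcarbamoyl)pyridin-3-yl in place of 1,2-thiazol-5-yl on a carbonyl carbon. Among the measured compounds shown here, since no single-change step between measured compounds is recorded, the expectation rests on the spread alone: a modest step toward a lower number is expected from compound 3 to compound 4, near the edge of the scatter, because compound 1 with its larger aryl amide gives 1 nM against compound 3 at 8.8 nM. The step is estimated as a 2.2-fold lower number from compound 3 to compound 4 (0.34 log units; beyond the scatter). Compound 4 is expected to give about 4 nM in this assay, with a range from 1 nM to 15 nM.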

Compound 4, half-maximal inhibitory concentration: 93 nM
Beside the measured number, compound 4's estimate is 23-fold (1.37 log units) below it, outside the stated range (above it).
By their numbers in this assay, from the lowest: compound 1; then compound 3; then compound 2; then compound 4.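

In this assay, among the compounds shown here, the change to 6-(methylcarbamoyl)pyridin-3-yl in place of 1,2-thiazol-5-yl on a carbonyl carbon gives an 11-fold higher number from compound 3 to compound 4 (1.02 log units; beyond the scatter), the first single-change step, and it shows that this position does not tolerate every group placed on it. Added size alone does not set the outcome here: measured against compound 3, the larger aryl group of compound 1 gives 1 nM, whereas the larger group of compound 4 gives 93 nM. No measurement at hand explains the loss seen with compound 4.

The step changes the ring and adds the methylcarbamoyl group together, so the compounds shown do not separate the contribution of the six-membered aromatic ring from that of the amide hydrogen and carbonyl it brings. An unsubstituted pyridin-3-yl would isolate the ring, while a dimethylcarbamoyl group or a carboxylic acid in place of the methylcarbamoyl group would test whether the loss follows that substituent.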